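Lengthening an Alkyl Chain on a Thiazole Nitrogen

The source may hold more compounds than are shown below. What is called first, only, known or untested is meant among the compounds shown, and "the series" means these compounds.

Compound 1 `CCN(Cc1ccc(C(=O)NO)cc1)c1ncc(-c2ccc(C)cc2)s1` gives 2700 nM in a functional assay on A549 cells (Homo sapiens) for antiproliferative activity, read by MTT assay, with a stated time of 48 h (a lower number here means a stronger inhibitor of growth, a higher number a weaker inhibitor of growth), the lowest of the three numbers measured. Compound 2 `CCCCCCCCN(Cc1ccc(C(=O)NO)cc1)c1ncc(-c2ccc(C)cc2)s1` gives 4630 nM, and compound 3 `Cc1ccc(-c2cnc(N(CCCCOc3ccccc3)Cc3ccc(C(=O)NO)cc3)s2)cc1` gives 14200 nM. Compound 4 `CCCCN(Cc1ccc(C(=O)NO)cc1)c1ncc(-c2ccc(C)cc2)s1` has not been measured; it differs from compound 1 by ethyl in place of hydrogen on a saturated chain carbon, two bonds along the chain from a nitrogen on an aromatic ring. Among the compounds with values here, two steps bear on this: a 1.7-fold higher number from compound 1 to compound 2 (0.23 log units; within the scatter), and a 5.3-fold higher number from compound 1 to compound 3 (0.72 log units; beyond the scatter). The change to compound 4 is a smaller version of the first of these, adding only part of what the hexyl added, and no ring. A step of at most the scatter is therefore expected, if anything toward a higher number, as a 1.2-fold higher number from compound 1 to compound 4 (0.09 log units; within the scatter). Compound 4 is estimated at 3300 nM, within a range from 1700 nM to 6500 nM.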

Compound 4, concentration for 50% growth inhibition: 4780 nM
The estimate for compound 4 lay 1.4-fold (0.16 log units) below the measured number, within the range that was stated.
By their numbers in this assay, from the lowest: compounds 1, 2 and 4 (each within the scatter of the next); then compound 3.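

In this assay, ethyl in place of hydrogen gives a 1.8-fold higher number from compound 1 to compound 4 (0.25 log units; within the scatter) and hydrogen in place of butyl gives a 1.0-fold higher number from compound 2 to compound 4 (0.01 log units; within the scatter) so neither step along this alkyl series lies beyond the scatter, and chain length across compound 1, compound 4 and compound 2 shows no clear effect on the number. Hydrogen in place of phenoxy, by contrast, gives a 3.0-fold lower number from compound 3 to compound 4 (0.47 log units; beyond the scatter) which is beyond the scatter, so the phenoxy group, and not chain length alone, sets compound 3 apart. No measurement shown here explains this difference.

From the compounds shown here alone, whether an amine or a carboxylic acid in place of the phenoxy would also shift the number remains open.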